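This account rests on a few compounds, and the source may have more. Where it says the series, first, only, none or still open, it means among the compounds named here.

Measured so far in an ADME assay for pharmacokinetics, read by LC-MS, in phosphate buffer, with a stated time of 72 h, at pH 7.4, tested at 250 uM; on this read-out lower numbers stand for a shorter-lived compound and higher numbers for a longer-lived compound:
Compound 1 `C=CC(=O)Oc1cc(C(F)(F)F)cc(C(F)(F)F)c1` gives < 0.017 h, a limit of the assay and not a number.
Compound 2 `C=CS(=O)(=O)c1cc(C(F)(F)F)cc(C(F)(F)F)c1` gives < 0.017 h, likewise a limit of the assay and not a number.

Compound 2 stands at the limit of this assay, so no number is known for it. The two measured values sit at the same limit (the limit of < 0.017 h in this assay, at which 2 of the 2 values shown sit). Among the measured compounds shown here, the one step between measured compounds, a step that the two limits leave unreadable from compound 1 to compound 2, cannot be read in size for that reason. Compound 3 `O=C1C=CC(=O)N1c1cc(C(F)(F)F)cc(C(F)(F)F)c1` differs from compound 2 by a group of 7 heavy atoms (4 carbon, 1 nitrogen, 2 oxygen; one five-membered non-aromatic ring with 1 hetero atom) in place of a group of 5 heavy atoms (2 carbon, 2 oxygen, 1 sulfur; no ring), on an aromatic carbon. No measured step bears on this change, and the only step between measured compounds is unreadable, so neither direction nor size of the step in this assay is anchored by anything shown. The estimate for compound 3 is 0.05 h, with a range from 0.01 h to 1 h. The expected step of an at least 2.9-fold higher number from compound 2 to compound 3 (0.46 log units; beyond the scatter) is accordingly loosely held, and a second reading at the limit remains a real possibility.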

Compound 3, half-life: < 0.017 h
Compound 3: no number, only a limit; the forecaster's own chance of this, stated with the estimate: 45%; middle value at least 2.9-fold (0.46 log units) from the limit.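

Compound 3 adds no readable step to compound 1 or compound 2 in this assay, as all three values are limits of the assay and not numbers: the limit of < 0.017 h in this assay, at which 3 of the 3 values shown sit.

The compounds shown leave open how far compound 1, compound 2 and compound 3 differ in half-life, and in which direction.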